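The compounds below may be only part of what the source reports. "The series", "measured", "known", "first", "only" and "open" are said of these compounds alone.

Compound 1 `COc1ccc(C(=O)c2cc(/C=C/C(=O)NO)n(C)c2)cc1` has the higher number of the two compounds measured in an assay on isolated protein for inhibition of histone deacetylase HD2 (Zea mays), tested at 30 uM; on this read-out lower numbers stand for less inhibition and higher numbers for more inhibition at the one concentration tested (going by the name of the read-out): compound 1 gives 75.2%, the highest of the two numbers at hand. Among the compounds with values here, the only other measured compound, compound 2 `Cn1cc(C(=O)c2ccccc2)cc1CCC(=O)NO`, gives 45% in this assay, a number that falls below that of compound 1 by more than the usual scatter. Within the data shown here, no pair of measured compounds differs in a single place, so no measured step can be drawn on.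

The unmeasured compound 3 `Cn1cc(C(=O)c2ccc(Cl)cc2)cc1/C=C/C(=O)NO` differs from compound 1 in one place: chloro in place of methoxy on an aromatic carbon. Since nothing measured speaks to this exchange, the step from compound 1 to compound 3 is expected to be small and downward, a number 7.2 percentage points lower from compound 1 to compound 3 (within the scatter), a change not clearly beyond the scatter. Compound 3 is accordingly estimated to reach 68% in this assay, with a range from 50% to 85%.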

Compound 3, a percentage reported as inhibition, at one concentration (the size of the read-out at that concentration, not a potency): 87%
Estimate against measurement, compound 3: 19 percentage points below; the measured number lies above the stated range.
By their numbers in this assay, from the lowest: compound 2; then compound 1; then compound 3.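

In this assay chloro in place of methoxy on the aromatic carbon para to a large group gives a number 11.8 percentage points higher from compound 1 to compound 3 (beyond the scatter) and so provides the first measured sign that the group at this place on the six-membered aromatic ring affects the read-out. The exchange also shows that the methoxy of compound 1 is not needed for a high number, since compound 3 carries a single chlorine there and no hydrogen-bond acceptor. Nothing at hand accounts for the rise.

As far as these compounds go, whether the rise is particular to chloro stays open, as a single exchange cannot tell how fluoro, methyl or an amine would read at the same place. The part played by the chain also remains unresolved, since compound 2 differs from both compound 1 and compound 3 in more than one place.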